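Chain Length and Branching in Three ACAT Inhibitors

A few compounds are considered here, and "the series" means these few. Any claim that something is new, unique, unknown or untested is made for them only; others in the source may bear on it.

The measured compounds:
compound 1, `CCCCCCCCOC(=O)NC(=O)Oc1c(C(C)C)cccc1C(C)C`, 250 nM;
compound 2, `CCCCCCCCCCCOC(=O)NC(=O)Oc1c(C(C)C)cccc1C(C)C`, 140 nM;
compound 3, `CCCCCCCCCCCCOC(=O)NC(=O)Oc1c(C(C)C)cccc1C(C)C`, 21 nM.

These values come from an assay on microsomes from intestine for inhibition of acyl-CoA:cholesterol acyltransferase (Oryctolagus cuniculus); a lower number here means a stronger inhibitor, a higher number a weaker inhibitor. Compound 3 differs from compound 2 by methyl in place of hydrogen on a saturated chain carbon, ten or more bonds along the chain from an oxygen next to a carbonyl group, and this gave a 6.7-fold lower number from compound 2 to compound 3 (0.82 log units; beyond the scatter). Compound 2 differs from compound 1 by hydrogen in place of propyl on a saturated chain carbon, eight bonds along the chain from an oxygen next to a carbonyl group.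

Compound 4, `CCCCCCCC(C)OC(=O)NC(=O)Oc1c(C(C)C)cccc1C(C)C`, is not yet measured. It differs from compound 1 by methyl in place of hydrogen on a saturated chain carbon bound to an oxygen next to a carbonyl group and a saturated chain carbon. This is the same kind of change as that from compound 2 to compound 3, but the place differs, as the two differences just given show: here the methyl sits on the carbon bound to the oxygen next to the carbonyl group. Among the compounds with values here, with no measured pair at this place, the earlier step is only a loose guide, and a smaller step of a 1.3-fold lower number from compound 1 to compound 4 (0.10 log units; within the scatter) is expected. Compound 4 is therefore estimated at 200 nM, between 60 nM and 650 nM.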

Compound 4, half-maximal inhibitory concentration: 97 nM
The estimate for compound 4 lay 2.1-fold (0.31 log units) above the measured number; the measured number falls inside the stated range.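

In this assay, methyl in place of hydrogen on the saturated chain carbon bound to the oxygen gave a 2.6-fold lower number from compound 1 to compound 4 (0.41 log units; beyond the scatter), so the number fell here as it did in the earlier methyl step. The sizes of the two steps cannot be told apart: the same change on two cores in this assay, a 6.7-fold lower number (0.82 log units; beyond the scatter) from compound 2 to compound 3 and a 2.6-fold lower number (0.41 log units; beyond the scatter) from compound 1 to compound 4, 2.6-fold (0.41 log units) apart, within the scatter of two such steps. Within the data shown here, this shows the same direction on two cores, but it rests on only two pairs with the methyl at different places, and it does not show that the step would keep its direction or size on a further core.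

Going by these compounds, it remains open whether an ethyl or phenyl group on that carbon would lower the number further. On these data alone, it is also open whether the methyl at that place would have the same effect on the longer chains of compound 2 and compound 3.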